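The source may hold more compounds than are shown below. What is called first, only, known or untested is meant among the compounds shown, and "the series" means these compounds.

Measured so far:
compound 1, `COc1ccc(C(F)(F)F)cc1CO[C@H]1[C@H](C(C)(C)C)[C@@H](C(=O)O)N(C(=O)C2CCCCC2)[C@H]1c1ccccc1`: 590%
compound 2, `COc1ncc(C(F)(F)F)cc1CO[C@H]1[C@H](C(C)(C)C)[C@@H](C(=O)O)N(C(=O)C2CCCCC2)[C@H]1c1ccccc1`: 650%

Both numbers come from an assay on cells with Cystic fibrosis transmembrane conductance regulator variant F508del (Homo sapiens) as the target, read by voltage clamp, with a stated time of 24 h, in the presence of a further agent that is not named here; on this read-out higher numbers stand for larger maximal responses and lower numbers for smaller maximal responses. Compound 2 stands highest of the two, the step of a number 60 percentage points higher from compound 1 to compound 2 (beyond the scatter) lying beyond the scatter. Compound 3, `COc1ncc(C2CCCC2)cc1CO[C@H]1[C@H](C(C)(C)C)[C@@H](C(=O)O)N(C(=O)C2CCCCC2)[C@H]1c1ccccc1`, differs from compound 2 by cyclopentyl in place of trifluoromethyl on an aromatic carbon. Going by the values given here, the only measured step, a number 60 percentage points higher from compound 1 to compound 2 (beyond the scatter), alters a different part of the structure and so offers no direct guide to this exchange. With nothing comparable measured, the step of a number 30 percentage points lower from compound 2 to compound 3 (beyond the scatter) is expected to stay within the scatter. Compound 3 is therefore estimated at 620%, within 400% to 820%.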

Compound 3, largest response reached (Emax), in percent of the reference or control that the assay uses: 203%
The estimate for compound 3 lay 417 percentage points above the measured number, outside the stated range (below it).
By their numbers in this assay, from the lowest: compound 3; then compound 1; then compound 2.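

In this assay, the aromatic carbon para to the methoxy group proves highly sensitive to what it carries: cyclopentyl in place of trifluoromethyl gives a number 447 percentage points lower from compound 2 to compound 3 (beyond the scatter). Neither group has hydrogen-bond donors or acceptors or a net charge, so those counts do not separate the two. No measurement available here accounts for this loss. 

On these data alone, how a methyl group, a chlorine atom or an amine on this same carbon would compare remains open. So does whether cyclopentyl would have a similar effect on compound 1.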